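One Carbon More in the Chain on the Methoxy Core

The compounds below may be only part of what the source reports. "The series", "measured", "known", "first", "only" and "open" are said of these compounds alone.

Three compounds have been measured in an assay on isolated protein for inhibition of protein deacetylase HDAC6 (Homo sapiens), with a stated time of 60 min, tested at 10 nM; on this read-out higher numbers stand for more inhibition at the one concentration tested (going by the name of the read-out) and lower numbers for less inhibition:

Compound 1 `O=C(CCCCCn1cc(Nc2ncc3ccn(Cc4ccc(F)cc4)c3n2)cn1)NO` gives 46%.
Compound 2 `O=C(CCCCCCn1cc(Nc2ncc3ccn(Cc4ccc(F)cc4)c3n2)cn1)NO` gives 62%.
Compound 3 `COc1ccc(Cn2ccc3cnc(Nc4cnn(CCCCCC(=O)NO)c4)nc32)cc1` gives 46%.

Compounds 1 and 3 share everything except one group on the ring at the far end: the difference is methoxy in place of fluoro on an aromatic carbon. This swap leaves the read-out where it was, no change at the digits printed from compound 1 to compound 3 (within the scatter), so the two cores behave alike in this assay as far as these two numbers show.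

Compounds 1 and 2 differ only in the chain that carries the hydroxycarbamoyl group, the change being ((hydroxycarbamoyl)methyl in place of hydroxycarbamoyl on a saturated chain carbon, five bonds along the chain from an aromatic nitrogen). Here the read-out moves: a number 16 percentage points higher from compound 1 to compound 2 (beyond the scatter).

Compound 4 `COc1ccc(Cn2ccc3cnc(Nc4cnn(CCCCCCC(=O)NO)c4)nc32)cc1` has not yet been measured. It stands to compound 3 as compound 2 stands to compound 1: the change is (hydroxycarbamoyl)methyl in place of hydroxycarbamoyl on a saturated chain carbon, five bonds along the chain from an aromatic nitrogen, and the place is described in the same words as for the change from compound 1 to compound 2, so it is the same change, made on the core that carries methoxy rather than fluoro.

For the measured compounds named here, because a number 16 percentage points higher from compound 1 to compound 2 (beyond the scatter) is the only measured example of this change, the step for compound 4 is expected to be of a similar size, about a number 16 percentage points higher from compound 3 to compound 4 (beyond the scatter). Compound 4 is therefore estimated at 62%, with a likely range from 48% to 76%. Whether the longer chain helps equally on both cores is exactly what the coming measurement will show.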

Compound 4, a percentage reported as inhibition, at one concentration (the size of the read-out at that concentration, not a potency): 40%
Compound 4: middle estimate off by 22 percentage points, on the high side; the measured number lies below the stated range.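

In this assay, the extra chain carbon did not carry over from the core with fluoro to the core with methoxy, where the step reads a number 6 percentage points lower from compound 3 to compound 4 (within the scatter), and set beside the earlier step it clearly differs: the same change on two cores in this assay, a number 16 percentage points higher (beyond the scatter) from compound 1 to compound 2 and a number 6 percentage points lower (within the scatter) from compound 3 to compound 4, 22 percentage points apart, beyond the scatter of two such steps

The same result appears when the comparison is read the other way, with methoxy in place of fluoro: on the longer chain this swap gives a number 22 percentage points lower from compound 2 to compound 4 (beyond the scatter), although it made no visible difference on the shorter chain: the same change on two cores in this assay, no change at the digits printed (within the scatter) from compound 1 to compound 3 and a number 22 percentage points lower (beyond the scatter) from compound 2 to compound 4, 22 percentage points apart, beyond the scatter of two such steps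

So, in these four compounds, the chain change and the ring change do not act independently, and a step measured on one core cannot simply be added to the other; this is still only one pair of pairs, with one percentage per compound at a single concentration, so it shows neither why the two changes interact nor whether other cores in the series would behave the same way.

The compounds shown leave open whether a still longer chain, or a shorter one, would separate the two cores further or bring them back together. They also leave open how a chloro or trifluoromethyl group in place of fluoro or methoxy would respond to the same chain change.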